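The source may report more compounds than this note shows. Statements on the series, on what has been measured and on what is new or still open speak of the compounds shown alone.

Measured so far:

- compound 1, `COc1ccc(C)cc1N1C(=O)CSC1c1cccc(C(=O)NCCCCc2ccccc2)c1`: 300 nM
- compound 2, `CC1SC(c2cccc(C(=O)NCCCCc3ccccc3)c2)N(c2ccc(C3CC3)cc2)C1=O`: 191 nM
- compound 3, `COc1ccccc1N1C(=O)CSC1c1cccc(C(=O)NCCCCn2cccn2)c1`: 91.7 nM

These three compounds share a core and were tested in a functional assay on HOS-TE85 cells (Homo sapiens) for inhibition, read by CCK-8 assay, with a stated time of 72 h; a lower number here means a stronger inhibitor, a higher number a weaker inhibitor. Among them compound 1 has the highest number. Its gap to compound 2 lies within the usual scatter of repeated measurements, so no order between the two can be claimed. Its gap to compound 3 lies beyond the scatter, so compound 3 is the stronger inhibitor of that pair.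

Compound 4, `COc1cc(F)ccc1N1C(=O)CSC1c1cccc(C(=O)NCCCCc2ccccc2)c1`, has not yet been measured in this assay. It differs from compound 1 in one place:

4-fluoro-2-methoxyphenyl in place of 2-methoxy-5-methylphenyl on an amide-type nitrogen in a ring

Among the measured compounds shown here, no measured pair in this set shows this kind of exchange, so there is no step to lean on. The expected step of a 1.1-fold lower number from compound 1 to compound 4 (0.03 log units; within the scatter) is small and not beyond the scatter in either direction. The value for compound 4 in this assay is estimated at 280 nM, with a plausible range from 110 nM to 750 nM.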

Compound 4, half-maximal inhibitory concentration: 71.1 nM
Beside the measured number, compound 4's estimate is 3.9-fold (0.60 log units) above it; measured number outside the range, below it.
By their numbers in this assay, from the lowest: compounds 4 and 3 (each within the scatter of the next); then compounds 2 and 1 (each within the scatter of the next).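

In this assay, exchanging 2-methoxy-5-methylphenyl for 4-fluoro-2-methoxyphenyl on the amide-type nitrogen gives a 4.2-fold lower number from compound 1 to compound 4 (0.63 log units; beyond the scatter), so this position responds to a change in the groups carried by the aromatic ring. Both groups have the same number of heavy atoms, the same single hydrogen-bond acceptor and no net charge, and both keep the methoxy group, so these counts do not separate them even though the numbers do. Nothing measured here explains the difference.

On these data alone, this single exchange removes a methyl group and adds a fluorine at once, so the share of each in the step remains unknown. As far as these compounds go, it also remains open whether a chlorine or a nitrile in place of the fluorine would give a similar number.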